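A few compounds are considered here, and "the series" means these few. Any claim that something is new, unique, unknown or untested is made for them only; others in the source may bear on it.

Compounds measured so far in a functional assay on DLD-1 cells (Homo sapiens) for cytotoxicity, with a stated time of 48 h; on this read-out lower numbers stand for stronger inhibition and higher numbers for weaker inhibition:
- compound 1 `Cc1ccc2oc(/C=C/[S+](C)[O-])cc(=O)c2c1`: 7000 nM
- compound 2 `CCCCC(=O)Oc1ccc2oc(/C=C/[S+](C)[O-])cc(=O)c2c1`: 6700 nM

Compound 2 gives 6700 nM, which lies within the scatter of the number for compound 1. The two cannot be ranked, and together they mark the only level seen so far. The next compound is compound 3 `C[S+]([O-])/C=C/c1cc(=O)c2cc(F)ccc2o1`, which carries fluoro in place of (butylcarbonyl)oxy on an aromatic carbon. Going by the values given here, only one measured step bears on this change: a 1.0-fold lower number from compound 1 to compound 2 (0.02 log units; within the scatter). That step exchanged methyl for (butylcarbonyl)oxy on an aromatic carbon and stayed within the scatter. Among the compounds with values here, no compound measured so far carries fluoro, so this evidence is indirect and the range must stay wide. On the strength of that single step, no change beyond the scatter is expected in this assay. The estimated step is a 1.0-fold lower number from compound 2 to compound 3 (0.01 log units; within the scatter), with no firm direction expected. For compound 3 the expected value is 6500 nM, with an estimated range from 2500 nM to 17000 nM.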

Compound 3, half-maximal inhibitory concentration: 7000 nM
For compound 3 the middle estimate is 1.1-fold (0.03 log units) below the measured one; the range from low to high includes it.
By their numbers in this assay, from the lowest: compounds 2, 1 and 3 (each within the scatter of the next).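

In this assay, fluoro in place of (butylcarbonyl)oxy gives a 1.0-fold higher number from compound 2 to compound 3 (0.02 log units; within the scatter), and fluoro in place of methyl gives no change at the digits printed from compound 1 to compound 3 (within the scatter). Fluoro is the first single-atom group in this series, and both steps that introduce it stay within the scatter, so methyl, (butylcarbonyl)oxy and fluoro on this aromatic carbon cannot be told apart by this read-out, a finding that holds only for these three compounds. The difference between the single fluorine atom and the much larger (butylcarbonyl)oxy group, which also brings hydrogen-bond acceptors, thus leaves no measurable mark here, and no measurement is available that would account for this flat result.

Whether any group at this place can shift the number beyond the scatter remains open, for instance an amine, a carboxylic acid or a phenyl ring, none of which appears among these compounds. The three compounds also differ only at this one aromatic carbon, so they say nothing about how changes elsewhere on the shared core would affect cytotoxicity.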